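A few compounds are considered here, and "the series" means these few. Any claim that something is new, unique, unknown or untested is made for them only; others in the source may bear on it.

Of the compounds shown here, three built on one shared core have been measured in a functional assay on A549 cells (Homo sapiens) for antiproliferative activity, read by MTT assay, with a stated time of 72 h; a higher number here means a weaker inhibitor, a lower number a stronger inhibitor. Compound 3 `COc1cc(N(C)CCN(C)C)c(NC(=O)c2ccncc2OC)cc1Nc1nccc(-c2cn(CCCO)c3ccccc23)n1` gives 2390 nM. Compound 1 `COc1cc(N(C)CCN(C)C)c(NC(=O)c2ccncn2)cc1Nc1nccc(-c2cn(C)c3ccccc23)n1` gives 2530 nM, and compound 2 `COc1cc(N(C)CCN(C)C)c(NC(=O)c2ccnc(Cl)c2)cc1Nc1nccc(-c2cn(CCCO)c3ccccc23)n1` gives 2140 nM. These three numbers all lie within the scatter of one another, so compound 3 cannot be set apart from either neighbour; no one of them stands out as stronger or weaker.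

Compound 4 `COc1cc(N(C)CCN(C)C)c(NC(=O)c2ccncn2)cc1Nc1nccc(-c2cn(CCCO)c3ccccc23)n1` has not been measured. It differs from compound 3 in one place: pyrimidin-4-yl in place of 3-methoxypyridin-4-yl on a carbonyl carbon. Compound 1 already carries this pyrimidin-4-yl group, though with a different chain on its indole nitrogen, and its number sits with the rest. For the measured compounds named here, the one measured step at the same place, a 1.1-fold higher number from compound 2 to compound 3 (0.05 log units; within the scatter), was also within the scatter. Together these suggest that swapping the group on the carbonyl carbon does little in this assay, so compound 4 is expected to show no step beyond the scatter, a 1.0-fold higher number from compound 3 to compound 4 (0.00 log units; within the scatter). Compound 4 is therefore estimated at 2400 nM, with a range of 1200 nM to 4800 nM.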

Compound 4, half-maximal inhibitory concentration: 2660 nM
Estimate against measurement, compound 4: 1.1-fold (0.04 log units) below, and the stated range covers the measured number.
By their numbers in this assay, from the lowest: compounds 2, 3, 1 and 4 (each within the scatter of the next).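

In this assay the pyrimidin-4-yl group on the carbonyl carbon is read directly against 3-methoxypyridin-4-yl (a 1.1-fold higher number from compound 3 to compound 4 (0.05 log units; within the scatter)) and against 2-chloropyridin-4-yl (a 1.2-fold higher number from compound 2 to compound 4 (0.09 log units; within the scatter)), so these three six-membered aromatic rings cannot be told apart at this place. The change at the other place, 2-hydroxyethyl in place of hydrogen on a saturated chain carbon bound to an aromatic nitrogen, can now also be read on its own with the pyrimidin-4-yl group held fixed (a 1.1-fold higher number from compound 1 to compound 4 (0.02 log units; within the scatter)), and it too stays within the scatter. No measurement shown here speaks to why these numbers stay so close.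

On these data alone, whether a ring carrying an amine or a carboxylic acid on the carbonyl carbon would move the number beyond the scatter remains open. So does the effect of a longer chain on the aromatic nitrogen.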